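A few compounds are considered here, and "the series" means these few. Any claim that something is new, unique, unknown or untested is made for them only; others in the source may bear on it.

Measured compounds:
compound 1 `CS(=O)(=O)Nc1ccc2c(c1)S(=O)(=O)N=C(c1c(O)c(-c3ccsc3)nn(CCC3CC3)c1=O)N2`, giving 0.517 h
compound 2 `CCCC(C)n1nc(-c2cccs2)c(O)c(C2=NS(=O)(=O)c3cc(NS(C)(=O)=O)ccc3N2)c1=O`, giving > 1 h

In an in vitro ADME assay on microsomes from liver (Homo sapiens) for metabolic stability, tested at 5 uM (on this read-out higher numbers stand for a longer-lived compound and lower numbers for a shorter-lived compound), compound 1 gives 0.517 h. For compound 2 the read-out is a limit of this assay and not a number: compound 2 gives > 1 h. For the measured compounds named here, compound 2 thus stands at the longer-lived end of the two values shown, at the limit (the limit of > 1 h in this assay, at which 1 of the 2 values shown sits), and no step between compound 1 and compound 2 is worked out here, since the two differ in more than one place.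

Compound 3 `CS(=O)(=O)Nc1ccc2c(c1)S(=O)(=O)N=C(c1c(O)c(-c3cccs3)nn(Cc3ccccc3)c1=O)N2` has not yet been measured in this assay. It differs from compound 2 in one place: benzyl in place of 1-methylbutyl on an aromatic nitrogen. Compound 3 is expected to sit close to compound 2, so the step of a number no higher from compound 2 to compound 3 (the limit leaves the size open) is estimated to be no larger than the usual scatter of this assay, in either direction. Compound 3 is therefore estimated to give 1 h, with a range from 0.4 h to 2.5 h, and there is a fair chance that this assay again reports only a limit for compound 3.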

Compound 3, half-life: > 1 h
Compound 3: only a limit was reported; the forecaster's own chance of this, stated with the estimate: 45%; the middle value sits exactly at the limit.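

Compound 2 and compound 3 both return only a limit, so no step can be read between them for benzyl in place of 1-methylbutyl on the aromatic nitrogen. The compounds shown leave open how long either compound actually lasts in this assay, and which of the two groups gives the longer half-life. The values shown crowd at one end: the limit of > 1 h in this assay, at which 2 of the 3 values shown sit.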